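Swapping a branched chain for a straight one on an amide nitrogen

A few compounds are considered here, and "the series" means these few. Any claim that something is new, unique, unknown or untested is made for them only; others in the source may bear on it.

Of the compounds shown here, three sharing one core have been tested in an ADME assay on microsomes from liver (Rattus norvegicus) for metabolic stability, with a stated time of 60 min; a lower number here means that less of the compound is left, a higher number that more of the compound is left. Compound 1, `O=C(O)c1cc(-c2cccc(COc3ccc4c(c3)CN(Cc3ccc(C(F)(F)F)cc3)C4=O)c2)ccc1Cl`, gives 100%. Compound 2, `O=C(O)c1cc(-c2cccc(COc3ccc4c(c3)CN(c3ccccc3)C4=O)c2)ccc1Cl`, gives 100%. Compound 3, `CC(C)N1Cc2cc(OCc3cccc(-c4ccc(Cl)c(C(=O)O)c4)c3)ccc2C1=O`, gives 91%. Among these three, compound 3 carries the smallest number, but the gaps are slight: a number 9 percentage points lower from compound 1 to compound 3 (within the scatter), and a number 9 percentage points lower from compound 2 to compound 3 (within the scatter), so compound 3 cannot be set apart from either of the others.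

Compound 4, `CCCN1Cc2cc(OCc3cccc(-c4ccc(Cl)c(C(=O)O)c4)c3)ccc2C1=O`, has not yet been measured in this assay. It differs from compound 3 in one place: propyl in place of isopropyl on an amide-type nitrogen in a ring.

For the measured compounds named here, two measured steps bear on this change, as each also replaces the group on the same amide-type nitrogen in a ring. Both of them, the step from compound 1 to compound 3 and the step from compound 2 to compound 3, stayed within the scatter, as did the step of no change at the digits printed from compound 1 to compound 2 (within the scatter). Large and small groups on this nitrogen have so far all left the number near the top of the scale, so no step beyond the scatter is expected here either. The step is estimated at a number 1 percentage points higher from compound 3 to compound 4 (within the scatter). Compound 4 is therefore expected to give about 92% in this assay, within a range from 78% to 100%.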

Compound 4, percent of the compound remaining: 96%
For compound 4 the middle estimate is 4 percentage points below the measured one; the measured number falls inside the stated range.
By their numbers in this assay, from the lowest: compounds 3, 4, 1 and 2 (each within the scatter of the next).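

In this assay, the same atoms joined differently, the branched isopropyl giving way to the straight propyl on an amide-type nitrogen in a ring, produce a number 5 percentage points higher from compound 3 to compound 4 (within the scatter), so the arrangement of this chain of 3 carbon atoms has no effect that can be told from the scatter. The straight chain also cannot be set apart from the two ring-bearing groups at this nitrogen, with a number 4 percentage points lower from compound 2 to compound 4 (within the scatter) and a number 4 percentage points lower from compound 1 to compound 4 (within the scatter), which adds a fourth group to those that cannot be separated here and shows that a change of chain shape, not just of chain type, fits the same picture. No measurement at hand speaks to a cause for these numbers.

The compounds shown leave open whether a longer chain such as hexyl, or a chain ending in an amine or a hydroxyl group, would still stay within the scatter of these four numbers at this nitrogen. They also leave open whether the number would hold if the chlorine on the shared core gave way to another group, such as methoxy, since every compound here carries that same chlorine.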